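This account rests on a few compounds, and the source may have more. Where it says the series, first, only, none or still open, it means among the compounds named here.

Compound 1 `Cn1c(Cc2nn(C)c(=O)c3ccccc23)nnc1SCC(=O)Nc1ccc(I)cc1` and compound 2 `Cn1c(Cc2nn(C)c(=O)c3ccccc23)nnc1SCC(=O)Nc1ccc(O)cc1` share a core with compound 3 `Cn1c(Cc2nn(C)c(=O)c3ccccc23)nnc1SCC(=O)Nc1ccc(Cl)cc1Cl` and compound 4 `Cn1c(Cc2nn(C)c(=O)c3ccccc23)nnc1SCC(=O)Nc1ccc(F)cc1F`. In an assay on isolated protein (Mus musculus) for inhibition of IL15-IL15 receptor (Homo sapiens), read by resazurin assay, with stated times of 30 min and 2.5 days (a higher number here means a weaker inhibitor, a lower number a stronger inhibitor), compound 1 gives "not active" (no number reported). In this assay compound 2 likewise gives "not active" (no number reported). Compound 3 is the only one of the three with a number, at 17300 nM in this assay, and so stands alone as the reference for the series. Compound 4 differs from compound 3 by 2,4-difluorophenyl in place of 2,4-dichlorophenyl on an amide-type nitrogen. Among the measured compounds shown here, with no measured step to lean on, the estimate from compound 3 to compound 4 is a 1.4-fold higher number from compound 3 to compound 4 (0.16 log units; within the scatter), expected to lie within the scatter or slightly toward weaker inhibition. Compound 4 is therefore expected at 25000 nM in this assay, with a range from 8000 nM to 80000 nM.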

Compound 4, half-maximal inhibitory concentration: "not active" (no number reported)
The entry for compound 4 holds no number; there is nothing to compare the estimate with.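

Among the compounds shown here, compound 4 carries no number in this assay and so no step from compound 3 to compound 4 can be read, and no evidence bears on this result. On these data alone, how far 2,4-difluorophenyl in place of 2,4-dichlorophenyl shifts inhibition stays open.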